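This account rests on a few compounds, and the source may have more. Where it says the series, first, only, none or still open, it means among the compounds named here.

The measured compounds are:
compound 1 `CC(=O)NC1CCCN(S(=O)(=O)c2ccc(F)cc2)C1`, 1 mg/kg;
compound 2 `CCC(=O)N1CCCC(NS(=O)(=O)c2ccc(F)cc2)C1`, 10 mg/kg;
compound 3 `CCC(=O)NC1CCCN(S(=O)(=O)c2ccc(F)cc2)C1`, 1 mg/kg.

All three were tested in a functional assay on the whole organism with Mus musculus as the target, with a stated time of 30 min; on this read-out lower numbers stand for an effect already at smaller amounts and higher numbers for an effect only at larger amounts of compound. Compound 1 and compound 3 share one core, and compound 2 is built from the same atoms joined differently; the difference between the two cores is not broken down here. Compound 1 is reached from compound 3 by hydrogen in place of methyl on a saturated chain carbon bound to a carbonyl carbon, and this step gave no change at the digits printed from compound 3 to compound 1 (within the scatter). In this assay compound 2 gives 10 mg/kg, a higher number than compound 1 with 1 mg/kg and than compound 3 with 1 mg/kg, both gaps being beyond the scatter.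

The unmeasured compound 4 `CC(=O)N1CCCC(NS(=O)(=O)c2ccc(F)cc2)C1` is reached from compound 2 by hydrogen in place of methyl on a saturated chain carbon bound to a carbonyl carbon, the same change as the one made on the other core. Because no change at the digits printed from compound 3 to compound 1 (within the scatter) showed no movement, compound 4 is expected to stay close to compound 2, with an estimated step of no change at the digits printed from compound 2 to compound 4 (within the scatter). In this assay compound 4 is therefore expected to give about 10 mg/kg, with a plausible range from 4 mg/kg to 25 mg/kg.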

Compound 4, minimum effective dose: 1 mg/kg
Compound 4: the middle estimate sits 10-fold (1.00 log units) above what was measured; the measured number lies below the stated range.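

In this assay, the change from propanoyl to acetyl, with hydrogen in place of methyl on a saturated chain carbon bound to a carbonyl carbon, gave a 10-fold lower number from compound 2 to compound 4 (1.00 log units; beyond the scatter). Set beside the earlier step, the same change did not carry over from one core to the other with the same size: the same change on two cores in this assay, no change at the digits printed (within the scatter) from compound 3 to compound 1 and a 10-fold lower number (1.00 log units; beyond the scatter) from compound 2 to compound 4, 10-fold (1.00 log units) apart, beyond the scatter of two such steps. Among these compounds, this shows that in these compounds the result of the change depends on the core that carries it, but with only one pair on each core it does not show what in the cores accounts for the difference, or how the change would behave on a further core.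

The compounds shown carry only propanoyl and acetyl on these two cores, so a longer chain such as butanoyl, or an amine or a carboxylic acid in that place, remains open. As far as these compounds go, whether a chloro or methoxy group in place of the fluoro group would act alike on both cores also remains open.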